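The compounds below may be only part of what the source reports. "The series", "measured", "known", "first", "only" and "open" are said of these compounds alone.

Measured in a functional assay on A549 cells (Homo sapiens) for cytotoxicity, read by MTT assay, with a stated time of 48 h; on this read-out higher numbers stand for weaker inhibition and lower numbers for stronger inhibition:
- compound 1 `C=C1C(=O)O[C@H]2CC3=C[C@H](C/C(C)=C/[C@@H](OC(=O)/C=C/c4ccccc4)[C@H]12)OC3=O`: 4800 nM
- compound 2 `C=C1C(=O)O[C@H]2CC3=C[C@H](C/C(C)=C/[C@@H](OC(=O)CCCCBr)[C@H]12)OC3=O`: > 10000 nM (a limit)

Compound 2 stands only at a limit, (the limit of > 10000 nM in this assay, at which 1 of the 2 values shown sits). Compound 3 `C=C1C(=O)O[C@H]2CC3=C[C@H](C/C(C)=C/[C@@H](OC(=O)C4CC4)[C@H]12)OC3=O` differs from compound 2 by cyclopropyl in place of 4-bromobutyl on a carbonyl carbon. Going by the values given here, the only measured step at this place is an at least 2.0-fold higher number from compound 1 to compound 2 (0.31 log units; beyond the scatter), with 4-bromobutyl in place of 2-phenylethenyl. Neither compound carries cyclopropyl, so that step gives a weak guide, and no change beyond the scatter is expected in this assay. The expected step is a number no higher from compound 2 to compound 3 (the limit leaves the size open). Compound 3 is estimated at 10000 nM, with an expected range of 4500 nM to 22000 nM.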

Compound 3, half-maximal inhibitory concentration: 3200 nM
The estimate for compound 3 lay 3.1-fold (0.49 log units) above the measured number; the whole stated range lies above it.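

In this assay, the step of an at least 3.1-fold lower number from compound 2 to compound 3 (0.49 log units; beyond the scatter) shows that replacing 4-bromobutyl with cyclopropyl on this carbonyl carbon gives a measurable value again. With a 1.5-fold lower number from compound 1 to compound 3 (0.18 log units; within the scatter), 2-phenylethenyl is not needed for activity at this place, as cyclopropyl and 2-phenylethenyl are not separated here. Compound 2 remains a limit, not a number: the limit of > 10000 nM in this assay, at which 1 of the 3 values shown sits.

On these data alone, whether the weak result for compound 2 goes with the bromine or with the chain stays open. Also open, as far as these compounds go, is how an unbrominated butyl chain, an amine or a carboxylic acid would read on this carbonyl carbon.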